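This account rests on a few compounds, and the source may have more. Where it says the series, first, only, none or still open, it means among the compounds named here.

Measured in an ADME assay on a cell-free system (plasma, Homo sapiens) for protein binding, read by HPLC:
- compound 1 `CS(=O)(=O)c1ccc(-c2cnc(N)c(-c3ccc(C(F)(F)F)c(F)c3)c2)cc1` gives 94.8%
- compound 2 `CS(=O)(=O)c1ccc(-c2cnc(N)c(-c3ccc(C(F)(F)F)cc3)c2)cc1` gives 96.2%
- compound 3 `Cc1ccc(-c2cc(-c3ccc(S(C)(=O)=O)cc3)cnc2N)c2cccnc12` gives 94.4%

Among the measured compounds shown here, compound 2 lies within the scatter of both compound 1 and compound 3, so these three values set no order among the compounds.

The step under study leads to compound 4 `CNC(=O)c1ccc(-c2cc(-c3ccc(S(C)(=O)=O)cc3)cnc2N)cc1` and puts methylcarbamoyl in place of trifluoromethyl on an aromatic carbon. For the measured compounds named here, only one measured step is available, a 1.4-fold lower unbound fraction from compound 1 to compound 2 (0.14 log units; within the scatter) (hydrogen in place of fluoro on an aromatic carbon). That step stays within the scatter, but it is a different exchange and offers only weak guidance. Going by the values given here, no measured compound carries methylcarbamoyl, so the expectation rests on the structural change alone, starting from compound 2 at 96.2% with a wide range. A change beyond the scatter is expected, towards more free compound, and the estimated size is a 2.9-fold higher unbound fraction from compound 2 to compound 4 (0.46 log units; beyond the scatter) (an expectation, untested by any measured pair). The estimate for compound 4 is 89% (expected range 78% to 95%).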

Compound 4, plasma protein binding: 81.8%
Beside the measured number, compound 4's estimate is 1.7-fold (0.22 log units) (unbound fraction) below it, within the range that was stated.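

Putting methylcarbamoyl in place of trifluoromethyl on an aromatic carbon para to a large group gives, in this assay, a 4.8-fold higher unbound fraction from compound 2 to compound 4 (0.68 log units; beyond the scatter). The only earlier step, a 1.4-fold lower unbound fraction from compound 1 to compound 2 (0.14 log units; within the scatter), stays within the scatter, so this carbon is the first place in the series shown where a single exchange moves the read-out beyond the scatter. Nothing available bears on why this exchange has this effect.

On these data alone, how a primary carboxamide, a dimethylcarbamoyl or a carboxylic acid on this carbon would compare with methylcarbamoyl remains open. Also open is whether a step of this size would recur with the fluoro group of compound 1 present, since the exchange is shown in only one pair.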